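The source may hold more compounds than are shown below. What is called first, only, known or untested is meant among the compounds shown, and "the series" means these compounds.

Series notes. In an assay on cells for antagonist activity at transient receptor potential cation channel subfamily V member 1 (Homo sapiens), read by FLIPR and calcium flux, with a stated time of 6 min (on this read-out higher numbers stand for weaker inhibition and lower numbers for stronger inhibition), compound 3 `CCCCN(C)c1cc(C(C)(C)C)ccc1CNC(=O)C(C)c1ccc(NS(C)(=O)=O)c(F)c1` gives 1 nM, the lowest of the three numbers. Compound 1 `CCCCCCSc1nc(C(C)(C)C)ccc1CNC(=O)C(C)c1ccc(NS(C)(=O)=O)c(F)c1` gives 1.5 nM, within the scatter of compound 3. Compound 2 `CC(C(=O)NCc1ccc(C(C)(C)C)nc1C1CCCCC1)c1ccc(NS(C)(=O)=O)c(F)c1` gives 3.1 nM, beyond the scatter from compound 3. Going by the values given here, the one measured single-point step is a 2.1-fold higher number from compound 1 to compound 2 (0.32 log units; beyond the scatter), a ring group replacing a chain at an aromatic carbon. Compound 4 `CC(C(=O)NCc1ccc(C(C)(C)C)cc1N1CCN(c2ccccc2)CC1)c1ccc(NS(C)(=O)=O)c(F)c1` differs from compound 3 by 4-phenylpiperazin-1-yl in place of butyl(methyl)amino on an aromatic carbon. Among the compounds with values here, that step is the only comparison bearing on a ring-for-chain swap on the core, and it was modest; a step of similar size, toward a higher number, is therefore expected, so a 3.0-fold higher number from compound 3 to compound 4 (0.48 log units; beyond the scatter) is the estimate. Compound 4 is expected at 3 nM, with a range of 1 nM to 12 nM.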

Compound 4, inhibition constant: 0.8 nM
Beside the measured number, compound 4's estimate is 3.8-fold (0.57 log units) above it; the whole stated range lies above it.
By their numbers in this assay, from the lowest: compounds 4, 3 and 1 (each within the scatter of the next); then compound 2.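

In this assay the swap gives a 1.3-fold lower number from compound 3 to compound 4 (0.10 log units; within the scatter) so on this aromatic carbon, ortho to a large group, the larger two-ring 4-phenylpiperazin-1-yl takes the place of butyl(methyl)amino with no readable change in the number. This position therefore accepts both an open-chain amino group and a much larger ring-bearing one. No measurement here accounts for this result. Open, from the compounds shown here alone, is whether piperazin-1-yl without the phenyl ring, or a phenyl ring carrying a carboxylic acid, would keep the number at this position.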